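Hydroxy for amino on the phenyl of a xanthine antagonist

The source may hold more compounds than are shown below. What is called first, only, known or untested is meant among the compounds shown, and "the series" means these compounds.

Measured so far:
compound 1 `CC(C)CCn1c(=O)c2nc[nH]c2n(CC(C)C)c1=O` — 13000 nM
compound 2 `Cn1c(=O)c2nc(-c3cccc(N)c3)[nH]c2n(C)c1=O` — 1100 nM
compound 3 `CCCn1c(=O)c2nc(-c3ccc(Cl)cc3N)[nH]c2n(CCC)c1=O` — 2.5 nM

Of the compounds shown here, three sharing one core have been tested in an assay on cell membranes for antagonist activity at adenosine receptor A1 (Rattus norvegicus); on this read-out higher numbers stand for weaker inhibition and lower numbers for stronger inhibition. Compound 1 gives 13000 nM in this assay. Compound 2 carries an aminophenyl group on the core and gives 1100 nM, which places it second highest of the three numbers: compound 1 sits at a higher number, beyond the scatter, while compound 3, with its different substitution on both the core and the phenyl ring, gives 2.5 nM, far lower and also beyond the scatter.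

The step now followed leads from compound 2 to compound 4 `Cn1c(=O)c2nc(-c3cccc(O)c3)[nH]c2n(C)c1=O`, not yet measured in this assay. The change is hydroxy in place of amino on an aromatic carbon, on an aromatic carbon of a six-membered aromatic ring of carbon only, meta to a large group. Among the measured compounds shown here, no measured pair in this set shows this exchange, so its size must be estimated rather than read. Because compound 2 gives 1100 nM and the swap keeps a single heavy atom with one donor and one acceptor, the expected step of a 1.2-fold lower number from compound 2 to compound 4 (0.09 log units; within the scatter) is small, in either direction, and not clearly beyond the scatter. Compound 4 is therefore estimated at 900 nM, within a range from 250 nM to 3500 nM.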

Compound 4, inhibition constant: 340 nM
Beside the measured number, compound 4's estimate is 2.6-fold (0.42 log units) above it, and the stated range covers the measured number.
By their numbers in this assay, from the lowest: compound 3; then compound 4; then compound 2; then compound 1.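

In this assay, among the compounds shown here, the exchange of amino for hydroxy gives the first comparison in this set between compounds that differ in one place only, and it amounts to (a 3.2-fold lower number from compound 2 to compound 4 (0.51 log units; beyond the scatter)). This shows that the aromatic carbon meta to a large group is sensitive to this change: the step is modest but beyond the scatter, and it favours hydroxy. The step appears even though the entering and leaving groups match in heavy-atom count, hydrogen-bond donors, hydrogen-bond acceptors and net charge, so those computed counts do not separate the two groups, and nothing available here bears on what lies behind the difference.

For the compounds shown here, whether hydroxy keeps this advantage over amino on a compound with propyl chains on the shared core, or at another place on the aromatic ring, remains open, as this single pair is the only evidence for the exchange. Also open, as far as these compounds go, is how other groups at this same place would compare, such as a methoxy group, a carboxylic acid or a longer chain.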